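The compounds below may be only part of what the source reports. "The series", "measured", "known", "first", "only" and "open" are said of these compounds alone.

Measured in an ADME assay on BJ cells (Homo sapiens) for cytotoxicity, with a stated time of 72 h; a higher number here means that more compound is needed for the effect, a lower number that less compound is needed:
- Compound 1 `Nc1cc2c(-n3nc(-c4ccccn4)nc3N)ncnc2cc1Cl`: 27000 nM
- Compound 2 `COc1cc2ncnc(-n3nc(-c4ccccn4)nc3N)c2cc1N`: "not determined" (no result reported)
- Compound 3 `CCOC(=O)CNc1nc(-n2nc(-c3ccccn3)nc2N)c2cc(OC)c(OC)cc2n1`: > 27000 nM, a limit and not a number

Among the measured compounds shown here, compound 2 therefore has no single number to stand on, and the only comparison available comes from the other two compounds. Compound 3 is the one further entry, and it stands at the limit of > 27000 nM in this assay, at which 1 of the 3 values shown sits. Compound 4 `CCN(CC)C(=O)COc1cc2c(-n3nc(-c4ccccn4)nc3N)ncnc2cc1OC` has not yet been measured. The change (diethylcarbamoyl)methoxy in place of amino on an aromatic carbon places (diethylcarbamoyl)methoxy in place of amino on an aromatic carbon, ortho to a methoxy group.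

For the measured compounds named here, no measured step covers this change, and no size can be read from compound 2 itself. The expectation rests on compound 1, which gives 27000 nM. Relative to that level, a shift beyond the usual scatter is not expected in this assay, and a report of only a limit is a real possibility. For compound 4 the expected value is 22000 nM, with an estimated range from 9000 nM to 40000 nM.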

Compound 4, half-maximal effective concentration: > 25000 nM
Compound 4: a limit, no number; the forecaster's own chance of this, stated with the estimate: 50%; middle value at least 1.1-fold (0.05 log units) away from the limit.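

Among the compounds shown here, compound 2 has no reported result and compound 4 gives > 25000 nM, a limit and not a number, so no step between them can be read. Still open, from the compounds shown here alone, is whether (diethylcarbamoyl)methoxy in place of amino shifts the half-maximal effective concentration in this assay, and by how much.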